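Aromatase series: chloro to cyano on the phenoxy ring

This account rests on a few compounds, and the source may have more. Where it says the series, first, only, none or still open, it means among the compounds named here.

Measured so far in an assay on isolated protein for inhibition of Aromatase (Homo sapiens), read by fluorescence and colorimetric assay, with a stated time of 30 min; a higher number here means a weaker inhibitor, a lower number a stronger inhibitor:
- compound 1 `N#Cc1ccc(C(c2ccc(C#N)cc2)n2cc(COc3ccc(Cl)cc3)nn2)cc1`: 16100 nM
- compound 2 `N#Cc1ccc(OCc2cn(C(c3ccc(C#N)cc3)c3ccc(C#N)cc3)nn2)cc1`: 4640 nM
- compound 3 `Clc1ccc(OCc2cn(Cc3ccccc3)nn2)cc1`: 5040 nM

Compound 4 `N#Cc1ccc(OCc2cn(Cc3ccccc3)nn2)cc1` is not yet measured in this assay. It differs from compound 3 by cyano in place of chloro on an aromatic carbon. The same change, at the same kind of place, is already measured once in the series, from compound 1 to compound 2: cyano in place of chloro on an aromatic carbon. That step gave a 3.5-fold lower number from compound 1 to compound 2 (0.54 log units; beyond the scatter). How the core of compound 3 differs from the core of compound 1 is not broken down here; the values of compound 3 and compound 2 lie within the scatter of each other, while compound 1 sits beyond the scatter from both.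

Among the measured compounds shown here, with only one measured instance of the change, the expectation for compound 4 rests on that single step. The step from compound 3 to compound 4 is expected to be a 3.0-fold lower number from compound 3 to compound 4 (0.47 log units; beyond the scatter), taken somewhat smaller than the measured one because a 3.5-fold lower number from compound 1 to compound 2 (0.54 log units; beyond the scatter) is a single observation on a different core. Compound 4 is therefore estimated at 1700 nM, with a likely range from 600 nM to 5000 nM.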

Compound 4, half-maximal inhibitory concentration: 1360 nM
Beside the measured number, compound 4's estimate is 1.3-fold (0.10 log units) above it, within the range that was stated.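

In this assay, cyano in place of chloro on an aromatic carbon gives a 3.7-fold lower number from compound 3 to compound 4 (0.57 log units; beyond the scatter), and the earlier step on the other core is of matching direction and size: the same change on two cores in this assay, a 3.5-fold lower number (0.54 log units; beyond the scatter) from compound 1 to compound 2 and a 3.7-fold lower number (0.57 log units; beyond the scatter) from compound 3 to compound 4, 1.1-fold (0.03 log units) apart, within the scatter of two such steps. Within this series, the change therefore carries from the core of compound 1 to the core of compound 3 without a detectable difference in its size, so the step measured on one core would have been a fair guide to the step on the other. Among the compounds shown here, this rests on only two pairs in one assay, however, so it does not establish that the step would hold on further cores, and it gives no explanation for the shift.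

Only chloro and cyano are shown at this place, which leaves open how an amine, a carboxylic acid or a methoxy group there would compare with them. Also open, from the compounds shown here alone, is whether cyano gives a similar step at any other place on the same ring.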